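The source may report more compounds than this note shows. Statements on the series, on what has been measured and on what is new or still open speak of the compounds shown alone.

In a functional assay for inhibition, with Homo sapiens as the target (a lower number here means tighter binding, a higher number weaker binding), compound 1 (`N#Cc1ccc(C2OCC(C/C=C\CCC(=O)O)C(c3cccnc3)O2)cc1`) gives 1290 nM and compound 2 (`Cc1ccc(OC(C)(C)C2OCC(C/C=C\CCC(=O)O)C(c3cccnc3)O2)cc1`) gives 631 nM as the lower of the two numbers, a gap just beyond the scatter. Compound 3 (`CC(C)(Oc1ccccc1[N+](=O)[O-])C1OCC(C/C=C\CCC(=O)O)C(c2cccnc2)O1`) is still unmeasured. It has 2-nitrophenyl in place of 4-methylphenyl on an oxygen on a saturated carbon, a change counted as 2-nitrophenyl in place of 4-methylphenyl on an oxygen on a saturated carbon in full. For the measured compounds named here, no measured step of this kind exists, so no shift beyond the scatter is expected in this assay, with a 1.3-fold lower number from compound 2 to compound 3 (0.10 log units; within the scatter) as the estimated step. For compound 3 the expected value is 500 nM within an estimated range of 160 nM to 1500 nM in this measurement.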

Compound 3, dissociation constant: 11.2 nM
Estimate against measurement, compound 3: 45-fold (1.65 log units) above, and the stated range ends above it.
By their numbers in this assay, from the lowest: compound 3; then compound 2; then compound 1.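

For the compounds shown here, the aryl group on this oxygen strongly affects the result in this assay: 2-nitrophenyl in place of 4-methylphenyl gives a 56-fold lower number from compound 2 to compound 3 (1.75 log units; beyond the scatter), a large step that the earlier compounds could not show. It places the strongest effect seen so far at this position, on the oxygen on a saturated carbon. No measurement at hand explains the step.

The compounds shown leave open whether 4-nitrophenyl, 2-methylphenyl or 2-aminophenyl on the same oxygen would give a similar number. Also open, from the compounds shown here alone, is how plain phenyl would compare.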